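Benzyl sulfide analogue in the whole-animal series

The source may report more compounds than this note shows. Statements on the series, on what has been measured and on what is new or still open speak of the compounds shown alone.

Measured compounds:
compound 1 `S=c1[nH]nc(Cc2ccc(Cl)cc2Oc2ccccc2Cl)[nH]1` gives 159% in a functional assay on the whole organism (strain NMRI) with Mus musculus as the target, with a stated time of 60 min, at a dose of 20 mg/kg by the intraperitoneal route; a lower number here means a weaker effect, a higher number a stronger effect of the compound at the dose given
compound 2 `CCCSc1nnc(Cc2ccccc2Oc2ccccc2)[nH]1` gives 158% in this assay
compound 3 `CCSc1nnc(Cc2ccc(Cl)cc2Oc2ccccc2Cl)[nH]1` gives 174% in this assay

Compound 3 stands highest of the three numbers in this assay; compound 1 is the nearest to it and compound 2 the furthest, both beyond the scatter. Among the compounds with values here, the one step recorded, a number 15 percentage points higher from compound 1 to compound 3 (beyond the scatter), replaces the thiol-bearing core of compound 1 with the ethylsulfanyl-bearing core of compound 3 and is a modest rise. Within the data shown here, compound 2 carries a propylsulfanyl group on a different aryl part, so its number is noted but no step to compound 3 is drawn.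

Compound 4 `Clc1ccc(Cc2nnc(SCc3ccccc3)[nH]2)c(Oc2ccccc2Cl)c1` differs from compound 3 only by phenyl in place of methyl on a saturated chain carbon bound to a sulfur. Among the measured compounds shown here, no recorded step changes the group on the saturated chain carbon bound to the sulfur, so the recorded steps bear on this change only indirectly: growing the sulfur substituent from hydrogen to ethyl raised the read-out, and the present change grows it further, to benzyl.

Compound 4 is therefore expected to stay near compound 3, with a step of a number 9 percentage points lower from compound 3 to compound 4 (within the scatter) that is likely within or only just beyond the scatter, in either direction. The estimate for compound 4 in this assay is 165%, ranging from 130% to 200%.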

Compound 4, a percentage reported as activity, at one dose (the size of the read-out at that dose, not a potency): 129%
Estimate against measurement, compound 4: 36 percentage points above; measured number outside the range, below it.
By their numbers in this assay, from the lowest: compound 4; then compounds 2 and 1 (each within the scatter of the next); then compound 3.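

In this assay the group on the sulfur proves to be a sensitive place: ethylsulfanyl to benzylsulfanyl gives a number 45 percentage points lower from compound 3 to compound 4 (beyond the scatter) as a large step, so this position does not tolerate every substituent equally. Read with a number 15 percentage points higher from compound 1 to compound 3 (beyond the scatter) on the same sulfur, this shows that the number does not keep rising as the substituent grows, since the two steps run in opposite directions. Within the data shown here, the earlier compounds showed only the rise, and the phenyl in place of methyl on the saturated chain carbon bound to the sulfur is the first change here to reverse it, though nothing measured for these compounds accounts for the fall.

As far as these compounds go, it remains open whether the drop follows from the aromatic ring itself or from the greater size of the group, which a cyclohexylmethyl group or a butyl chain on the sulfur of the same core would help separate. Also open, from the compounds shown here alone, is how much of the higher number of compound 3 is specific to ethyl, as methyl or a propyl chain on this core would show. The propylsulfanyl compound 2 carries a different aryl part.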